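A few compounds are considered here, and "the series" means these few. Any claim that something is new, unique, unknown or untested is made for them only; others in the source may bear on it.

Compound 1, `Cc1c(NC(=O)C(C)Cl)cccc1C(=O)NC(N)=O`: in a functional assay on CCRF-CEM cells (Homo sapiens) for antiproliferative activity, read by trypan blue exclusion, with a stated time of 72 h (on this read-out lower numbers stand for stronger inhibition and higher numbers for weaker inhibition), compound 1 gives > 20000 nM.
Compound 2, `Cc1c(NC(=O)CCl)cccc1C(=O)NC(N)=O`: in this assay compound 2 gives 2700 nM.
Compound 3, `CC(Br)C(=O)Nc1ccc(C(=O)NC(N)=O)o1`: in this assay compound 3 gives 9440 nM.

The value of compound 1 is a limit of the assay rather than a number (the limit of > 20000 nM in this assay, at which 1 of the 3 values shown sits). Between compound 1 and compound 2 the change is hydrogen in place of methyl on a saturated chain carbon bound to a carbonyl carbon and a chlorine atom, and it made an at least 7.4-fold lower number from compound 1 to compound 2 (0.86 log units; beyond the scatter). Compound 3 stands on a different core from compound 1; the difference between the two cores is not broken down here. Compound 3 gives a higher number than compound 2 in this assay.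

Compound 4, `NC(=O)NC(=O)c1ccc(NC(=O)CBr)o1`, has not yet been measured. It differs from compound 3 by hydrogen in place of methyl on a saturated chain carbon bound to a bromine atom and a carbonyl carbon. Among the compounds with values here, this is the same kind of change as the one from compound 1 to compound 2, but here the carbon is bound to a bromine atom and a carbonyl carbon, rather than to a carbonyl carbon and a chlorine atom. Beside an at least 7.4-fold lower number from compound 1 to compound 2 (0.86 log units; beyond the scatter), the expected step in this assay is a 3.8-fold lower number from compound 3 to compound 4 (0.58 log units; beyond the scatter). That expectation rests on an at least 7.4-fold lower number from compound 1 to compound 2 (0.86 log units; beyond the scatter) and on compound 3 at 9440 nM. For compound 4 the estimate in this assay is 2500 nM, between 800 nM and 7000 nM.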

Compound 4, half-maximal inhibitory concentration: 4050 nM
The estimate for compound 4 lay 1.6-fold (0.21 log units) below the measured number, and the stated range covers the measured number.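

The change from 1-bromoethyl to bromomethyl gave a 2.3-fold lower number from compound 3 to compound 4 (0.37 log units; beyond the scatter) in this assay, so hydrogen in place of methyl lowered the number on both cores, but the size of the step did not carry over: the same change on two cores in this assay, an at least 7.4-fold lower number (0.86 log units; beyond the scatter) from compound 1 to compound 2 and a 2.3-fold lower number (0.37 log units; beyond the scatter) from compound 3 to compound 4, at least 3.1-fold (0.50 log units) apart, beyond the scatter of two such steps

The earlier step rests on a limit of the assay and not on a number, so its full size remains unknown, and the gap in size is likewise only a minimum: the limit of > 20000 nM in this assay, at which 1 of the 4 values shown sits.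

The two pairs also differ in the halogen on that carbon, chlorine in one and bromine in the other, and these compounds do not show whether the core, the halogen or both set the gap.

The compounds shown leave open how the same change behaves with a chlorine atom on the core of compound 3 or a bromine atom on the core of compound 1. They also leave open what a longer chain on that carbon, or an amine in place of the halogen, would do on either core.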